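A few compounds are considered here, and "the series" means these few. Any claim that something is new, unique, unknown or untested is made for them only; others in the source may bear on it.

Measured so far:
Compound 1 `O=C1C(Nc2ccc(Br)cc2)=CC(=O)c2c1nc1n2[C@H]2OC[C@@H](O)[C@H]2OC1` — in a functional assay on MGC-803 cells (Homo sapiens) for inhibition, read by sulforhodamine B assay (a higher number here means a weaker inhibitor, a lower number a stronger inhibitor), compound 1 gives 2020 nM.
Compound 2 `COc1ccccc1NC1=CC(=O)c2c(nc3n2[C@H]2OC[C@@H](O)[C@H]2OC3)C1=O` — in this assay compound 2 gives 1670 nM.
Compound 3 `COc1ccccc1NC1=CC(=O)c2nc3n(c2C1=O)[C@H]1OC[C@@H](O)[C@H]1OC3` — in this assay compound 3 gives 1630 nM.

Compound 2 and compound 3 are built from the same atoms joined differently; the difference between the two cores is not broken down here, and their two values lie within the usual scatter of each other.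

One structural change has been measured once. From compound 2 to compound 1 the change is 4-bromophenyl in place of 2-methoxyphenyl on an amine nitrogen and the step is a 1.2-fold higher number from compound 2 to compound 1 (0.08 log units; within the scatter), within the scatter.

Compound 4 `O=C1C=C(Nc2ccc(Br)cc2)C(=O)c2c1nc1n2[C@H]2OC[C@@H](O)[C@H]2OC1` has not been measured. It differs from compound 3 by 4-bromophenyl in place of 2-methoxyphenyl on an amine nitrogen, the same change at the same kind of place.

From compound 3 to compound 4 a step of about a 1.2-fold higher number from compound 3 to compound 4 (0.08 log units; within the scatter) is expected in this assay, because the same change gave a 1.2-fold higher number from compound 2 to compound 1 (0.08 log units; within the scatter) on the other core. Compound 4 is therefore estimated at 1950 nM, with a likely range from 1100 nM to 3500 nM.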

Compound 4, half-maximal inhibitory concentration: 1010 nM
Estimate against measurement, compound 4: 1.9-fold (0.29 log units) above, and the stated range ends above it.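

Putting 4-bromophenyl in place of 2-methoxyphenyl on the amine nitrogen gives a 1.6-fold lower number from compound 3 to compound 4 (0.21 log units; within the scatter) in this assay on the core of compound 3. With one pair on each core and every step inside the usual scatter, this does not show that the change truly raises or lowers the number on either core, or how it would behave on a third core. What it does show is that the two cores give no measurable disagreement about this change:  the same change on two cores in this assay, a 1.2-fold higher number (0.08 log units; within the scatter) from compound 2 to compound 1 and a 1.6-fold lower number (0.21 log units; within the scatter) from compound 3 to compound 4, 2.0-fold (0.29 log units) apart, within the scatter of two such steps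

The compounds shown carry only these two substituted phenyl groups on the amine nitrogen. From the compounds shown here alone, whether a simple alkyl chain, a morpholine or a phenyl ring bearing a carboxylic acid would move the number beyond the scatter remains open.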